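Trifluoromethyl in place of ethyl, from compound 3 to compound 4

The source may report more compounds than this note shows. Statements on the series, on what has been measured and on what is new or still open speak of the compounds shown alone.

Within the data shown here, compound 3 `CCc1ccc(NC(=O)N[C@@H](C)c2ccccc2)cc1` gives 95% in an ADME assay on the whole organism with Oryza sativa as the target, tested at 1 uM (a higher number here means a weaker effect of the compound at the concentration tested, a lower number a stronger effect), the highest of the three numbers so far. Compound 1 `CCc1cccc(NC(=O)N[C@@H](C)c2ccccc2)c1` gives 94% in this assay, within the scatter of compound 3. Compound 2 `CCc1ccc(NC(=O)N[C@H](C)c2ccccc2)cc1` gives 47% in this assay; the step of a number 48 percentage points higher from compound 2 to compound 3 (beyond the scatter) is the one large movement in the set, and it rests on (the fact that compounds 2 and 3 differ only in the configuration as drawn). Among the measured compounds shown here, that step concerns configuration only and says nothing about a change of the group on the aromatic ring, so no measured step bears directly on the change to compound 4.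

Compound 4 `C[C@H](NC(=O)Nc1ccc(C(F)(F)F)cc1)c1ccccc1` differs from compound 3 by trifluoromethyl in place of ethyl on an aromatic carbon. Compound 3 already stands near the top of the range, leaving little room upward, and nothing measured points to a drop; the expected step of a number 7 percentage points lower from compound 3 to compound 4 (within the scatter) is therefore small, within the scatter. Compound 4 is expected to give about 88% in this assay, estimated between 60% and 100%.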

Compound 4, a percentage reported as activity, at one concentration (the size of the read-out at that concentration, not a potency): 94%
Compound 4: the middle estimate sits 6 percentage points below what was measured, and the stated range covers the measured number.
By their numbers in this assay, from the lowest: compound 2; then compounds 1, 4 and 3 (each within the scatter of the next).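

In this assay, trifluoromethyl in place of ethyl on an aromatic carbon, para to a large group, gives a number 1 percentage points lower from compound 3 to compound 4 (within the scatter), so this position takes the change from ethyl to trifluoromethyl with no step beyond the scatter. Among these compounds, the only large step among the earlier compounds was a change of configuration, whereas this pair reads a change of group with the configuration as drawn left out of the comparison, and both compounds stay at the weak-effect end of the numbers. Nothing on hand bears on why this exchange leaves the number in place.

Still open, as far as these compounds go, is whether the trifluoromethyl compound drawn with the opposite configuration would show the stronger effect seen for compound 2 at 47%. Also open, from the compounds shown here alone, is how an amine, a carboxylic acid or a longer chain at this position would read in this assay.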